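The source may hold more compounds than are shown below. What is called first, only, known or untested is meant among the compounds shown, and "the series" means these compounds.

Compound 2 `CC1=CC(=O)N(Nc2nc(-c3cccs3)ncc2-c2nc(C)co2)C1=O` gives 200 nM in a functional assay on Jurkat cells for inhibition of nuclear factor NF-kappa-B complex (Homo sapiens) (on this read-out higher numbers stand for weaker inhibition and lower numbers for stronger inhibition), the highest of the two numbers at hand. Going by the values given here, its only measured neighbour is compound 1 `CCOC(=O)c1cnc(-c2cccs2)nc1NN1C(=O)C=C(C)C1=O`, which in this assay gives 20 nM. The step of a 10-fold higher number from compound 1 to compound 2 (1.00 log units; beyond the scatter) separates the two, and it consists of 4-methyl-1,3-oxazol-2-yl in place of ethoxycarbonyl on an aromatic carbon of the shared core.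

Compound 3 `CC1=CC(=O)N(Nc2nc(-c3cccs3)ncc2-c2nnc(C)o2)C1=O` has not yet been measured. It differs from compound 2 by 5-methyl-1,3,4-oxadiazol-2-yl in place of 4-methyl-1,3-oxazol-2-yl on an aromatic carbon. Among the compounds with values here, no measured step bears directly on this change: the one step on record exchanges a wholly different group on the same aromatic carbon and says nothing about trading one five-membered aromatic ring for another. Within the data shown here, with no bearing step, the expectation is a move in this assay that does not go beyond the scatter in either direction.

For compound 3 the estimate in this assay is therefore 200 nM, with a range from 70 nM to 600 nM. The expected step is no change at the digits printed from compound 2 to compound 3 (within the scatter), which amounts to essentially no change.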

Compound 3, half-maximal inhibitory concentration: 300 nM
Estimate against measurement, compound 3: 1.5-fold (0.18 log units) below, and the stated range covers the measured number.
By their numbers in this assay, from the lowest: compound 1; then compounds 2 and 3 (each within the scatter of the next).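

In this assay, the new step at this aromatic carbon, which lies para to the thiophen-2-yl group, is a 1.5-fold higher number from compound 2 to compound 3 (0.18 log units; within the scatter); on this evidence, 4-methyl-1,3-oxazol-2-yl and 5-methyl-1,3,4-oxadiazol-2-yl, five-membered aromatic rings with 2 and 3 hetero atoms, cannot be told apart. The second ring also leaves the number well away from that of the ethoxycarbonyl compound, with a 15-fold higher number from compound 1 to compound 3 (1.18 log units; beyond the scatter), so compound 1 now stands beyond the scatter from both ring-bearing compounds, and neither ring comes close to it. No measurement at hand speaks to the reason for either step.

Still open, going by these compounds, is whether the low number of compound 1 is particular to ethoxycarbonyl or would persist with a methyl ester, a carboxylic acid or a primary amide on the same carbon. Both rings shown carry a methyl group, so it also remains open how an unsubstituted 1,3,4-oxadiazol-2-yl ring or one bearing an ethyl group or an amine would read out here.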